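The source may hold more compounds than are shown below. What is called first, only, known or untested is meant among the compounds shown, and "the series" means these compounds.

Measured compounds in a functional assay on CHO-K1 cells for antagonist activity at transient receptor potential cation channel subfamily V member 1 (Homo sapiens), read by FLIPR; a higher number here means a weaker inhibitor, a lower number a stronger inhibitor:
compound 1, `CCCCN(C)c1nc(C(F)(F)F)ccc1CNC(=O)C(C)c1ccc(NS(C)(=O)=O)c(F)c1` — 0.8 nM
compound 2, `C[C@H](C(=O)NCc1ccc(C(F)(F)F)nc1N1CC[C@H](N(C)C)C1)c1ccc(NS(C)(=O)=O)c(F)c1` — 103 nM

Compound 1 gives the lowest of the two numbers in this assay; compound 2 sits at a far higher number, and the gap between the two is well beyond the scatter. For the measured compounds named here, no single-change step connects compound 1 and compound 2, so the pair shows only that the two values lie far apart.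

Compound 3, `CC(C(=O)NCc1ccc(C(F)(F)F)nc1N1CCCCCCC1)c1ccc(NS(C)(=O)=O)c(F)c1`, has not been measured. It differs from compound 1 in one place: a group of 8 heavy atoms (7 carbon, 1 nitrogen; one eight-membered non-aromatic ring with 1 hetero atom) in place of a group of 6 heavy atoms (5 carbon, 1 nitrogen; no ring), on an aromatic carbon. The change keeps the nitrogen attached to the aromatic carbon and the single hydrogen-bond acceptor, and exchanges an open chain for an eight-membered non-aromatic ring with one hetero atom.

With no measured step of this kind in the series, the expectation for this assay is a modest move toward a higher number, of a size that may not clear the scatter; a large shift like the gap to compound 2 is not expected. For compound 3 the estimated value is 2.5 nM, with a range from 0.5 nM to 15 nM, which corresponds to an expected step of a 3.1-fold higher number from compound 1 to compound 3 (0.49 log units; beyond the scatter).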

Compound 3, inhibition constant: 0.7 nM
Estimate against measurement, compound 3: 3.6-fold (0.55 log units) above; measured number inside the range.
By their numbers in this assay, from the lowest: compounds 3 and 1 (each within the scatter of the next); then compound 2.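

In this assay, exchanging butyl(methyl)amino for the eight-membered non-aromatic ring, on the aromatic carbon next to the ring nitrogen, gives a 1.1-fold lower number from compound 1 to compound 3 (0.06 log units; within the scatter) and so leaves the value in place. For the compounds shown here, this is the first single-change step at this position, and it shows that the open chain is not needed to keep a value at the level of compound 1: a group with two more heavy atoms, tied into a ring and still attached through nitrogen, is accepted here without a change that can be told from scatter. No measured property of either group is available to account for the two compounds standing level.

On these data alone, a single ring size gives no trend, so it remains open whether the flat response at this position extends to a pyrrolidine, a piperidine or a morpholine, or to a longer open chain such as dibutylamino. As far as these compounds go, it is also open whether a carbon-linked group, such as cyclohexyl in place of the attached nitrogen, would hold the value in this assay at this position.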